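A few compounds are considered here, and "the series" means these few. Any claim that something is new, unique, unknown or untested is made for them only; others in the source may bear on it.

Measured compounds:
`CC(C)=CCOc1cc(Nc2nc(C)cc(N)n2)ccc1Cl` compound 1, in a functional assay on MT2 cells (Homo sapiens) for cytotoxicity, read by MTT assay (on this read-out higher numbers stand for lower toxicity in this test and lower numbers for higher toxicity in this test), compound 1 gives < 4 nM; this is a limit of the assay, not a number.
`CC(C)=CCOc1cc(Nc2nc(N)cc(Cl)n2)ccc1Cl` compound 2, in this assay compound 2 gives 14 nM.

Among the measured compounds shown here, compound 2 is the only compound with a number in this assay; the other value is a limit (the limit of < 4 nM in this assay, at which 1 of the 2 values shown sits). For the measured compounds named here, the one measured step runs from compound 1 to compound 2: an at least 3.5-fold higher number from compound 1 to compound 2 (0.54 log units; beyond the scatter).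

Compound 3 is `COc1cc(N)nc(Nc2ccc(Cl)c(OCC=C(C)C)c2)n1`. It differs from compound 2 at the same aromatic carbon that the measured step changed: methoxy in place of chloro on an aromatic carbon. The measured step bears on it only loosely, since it exchanged methyl for chloro, not chloro for methoxy. Going by the values given here, there is no measured pair that tells how methoxy compares with chloro here. The expected step is therefore small, no change at the digits printed from compound 2 to compound 3 (within the scatter), with no confident direction. Compound 3 is estimated at 14 nM in this assay, with a range from 4 nM to 50 nM.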

Compound 3, half-maximal cytotoxic concentration: 19000 nM
The estimate for compound 3 lay 1400-fold (3.13 log units) below the measured number; measured number outside the range, above it.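

Methoxy in place of chloro on this aromatic carbon gives a 1400-fold higher number from compound 2 to compound 3 (3.13 log units; beyond the scatter), so in this assay this position can carry a far larger change than the exchange of methyl for chloro had shown. Methoxy in place of methyl gives an at least 4700-fold higher number from compound 1 to compound 3 (3.67 log units; beyond the scatter), which leaves compound 3 much less toxic in this test than either of the other two compounds. That step starts from compound 1, whose entry is a limit of the assay and not a number: the limit of < 4 nM in this assay, at which 1 of the 3 values shown sits.

From the compounds shown here alone, whether an ethoxy group, a hydroxyl group or a fluorine on the same carbon would fall near compound 2 or near compound 3 remains open. Going by these compounds, it is also open whether the exchange of chloro for methoxy would give a step of this size with a dimethylamino group in place of the amino group.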